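The source may report more compounds than this note shows. Statements on the series, on what has been measured and on what is new or still open speak of the compounds shown alone.

Measured compounds:
- compound 1, `O=C(/C=C/C(=O)N1C/C(=C\c2ccccc2)C(=O)/C(=C/c2ccccc2)C1)Nc1ccc([N+](=O)[O-])cc1`: 31000 nM
- compound 2, `CC(=O)c1ccc(NC(=O)/C=C/C(=O)N2C/C(=C\c3ccc([N+](=O)[O-])cc3)C(=O)/C(=C/c3ccc([N+](=O)[O-])cc3)C2)cc1`: 390 nM

In a functional assay on Molt4/C8 cells (Homo sapiens) for cytotoxicity (on this read-out lower numbers stand for stronger inhibition and higher numbers for weaker inhibition), compound 1 gives 31000 nM, the highest of the two numbers and thus the weakest cytotoxicity seen here. Compound 2 gives 390 nM, a far lower number that lies beyond the scatter; the two structures differ in several places at once, so no single change can be credited for the gap.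

Compound 3, `COc1ccc(NC(=O)/C=C/C(=O)N2C/C(=C\c3ccccc3)C(=O)/C(=C/c3ccccc3)C2)cc1`, differs from compound 1 in one place only: methoxy in place of nitro on an aromatic carbon. Within the data shown here, no measured pair isolates this change, so the expectation rests on compound 1 alone and on the fact that a single substituent is swapped for another of similar size. The step of a 1.6-fold lower number from compound 1 to compound 3 (0.19 log units; within the scatter) is expected to be small, within the scatter, with no firm direction. Compound 3 is therefore estimated at about 20000 nM, with a range from 5000 nM to 80000 nM.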

Compound 3, half-maximal inhibitory concentration: 1100 nM
Beside the measured number, compound 3's estimate is 18-fold (1.26 log units) above it; measured number below the stated range.
By their numbers in this assay, from the lowest: compound 2; then compound 3; then compound 1.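

In this assay, putting methoxy in place of nitro on this aromatic carbon, para to a large group, gives a 28-fold lower number from compound 1 to compound 3 (1.45 log units; beyond the scatter). Among these compounds, this is the first clean view of this position: the earlier pair differed in several places at once, whereas here the rest of the structure stays the same, so this one swap accounts for the whole step. Nothing at hand explains the size of this step, so it stands as an observation.

A single pair cannot separate the loss of nitro from the arrival of methoxy, nor show where an amine, a chlorine or a longer chain such as ethoxy would fall at this position. It also leaves open whether the same swap would give a step of similar size with other groups on the remaining aromatic rings.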